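The source may report more compounds than this note shows. Statements on the series, on what has been measured and on what is new or still open speak of the compounds shown alone.

Compound 1 `O=c1ccc2cc(OCc3cc(-c4ccccc4Cl)no3)ccc2o1` carries a 2-chlorophenyl group on the shared core, and in a functional assay on HCT-116 cells (Homo sapiens) for cytotoxicity, read by MTT assay, with a stated time of 48 h (on this read-out higher numbers stand for weaker inhibition and lower numbers for stronger inhibition), compound 1 is recorded as "not determined" (no result reported), so no number is available for it. Compound 2 `O=c1ccc2cc(OCc3cc(-c4cccc(Cl)c4)no3)ccc2o1` bears a 3-chlorophenyl group, and in this assay compound 2 gives 42100 nM. Compound 3 `O=c1ccc2cc(OCc3cc(-c4ccc(Cl)cc4)no3)ccc2o1` bears a 4-chlorophenyl group, and in this assay compound 3 gives 55800 nM. The step of a 1.3-fold higher number from compound 2 to compound 3 (0.12 log units; within the scatter) shows that moving the chloro group around the phenyl ring makes no difference beyond the scatter. Compound 3 therefore stands at the higher of the two numbers, yet it cannot be told apart from compound 2 on these data.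

Compound 4 `O=c1ccc2cc(OCc3cc(-c4ccc([N+](=O)[O-])cc4)no3)ccc2o1` differs from compound 3 by nitro in place of chloro on an aromatic carbon. Among the measured compounds shown here, no measured step swaps one substituent for another on that ring; the single step that exists, from compound 2 to compound 3, concerns only the position of the chloro group and lies within the scatter. With nothing pointing in either direction, the expectation for this assay is a step of about a 1.2-fold lower number from compound 3 to compound 4 (0.07 log units; within the scatter), that is, no change beyond the scatter. Compound 4 is thus estimated to give 48000 nM, within a range of 15000 nM to 150000 nM.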

Compound 4, half-maximal inhibitory concentration: 42200 nM
Estimate against measurement, compound 4: 1.1-fold (0.06 log units) above, and the stated range covers the measured number.
By their numbers in this assay, from the lowest: compounds 2, 4 and 3 (each within the scatter of the next).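

In this assay, among the compounds shown here, the step to 4-nitrophenyl from 4-chlorophenyl, a 1.3-fold lower number from compound 3 to compound 4 (0.12 log units; within the scatter), is the first exchange of one substituent for another on this ring, and it stays within the scatter, as the earlier shift of the chloro group did. The second new step, a 1.0-fold higher number from compound 2 to compound 4 (0.00 log units; within the scatter), is also within the scatter, so changing both the group and its place on the ring gives no separation either. At this position on an aromatic carbon, para to a large group, three heavy atoms of nitro with two hydrogen-bond acceptors in place of one chlorine therefore leave the number within the scatter of those for the two chloro compounds, and no measurement shown here offers any explanation for this.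

The steps to compound 1 cannot be read, so the 2-chlorophenyl group remains unplaced relative to the others. Whether any group at this position can move the number beyond the scatter also stays open, for instance an amine, a carboxylic acid or a longer chain such as butyl, since the substituents shown are limited to chloro and nitro.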